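The source may hold more compounds than are shown below. What is called first, only, known or untested is meant among the compounds shown, and "the series" means these compounds.

In an ADME assay on HOS cells (Homo sapiens) for cytotoxicity (on this read-out higher numbers stand for weaker inhibition and lower numbers for stronger inhibition), compound 1 (`O=C1c2c(ccc(O)c2O)CN1Cc1ccccc1`) has the entry "not determined" (no result reported) and so offers no number for comparison. Compound 2 (`O=C1c2c(ccc(O)c2O)CN1Cc1cccc(Cl)c1`) gives 9020 nM in this assay. Among the measured compounds shown here, this is the only number, so compound 2 can be ranked against nothing else. Compound 3 (`O=C1c2c(ccc(O)c2O)CN1Cc1cccc(I)c1`) has not yet been measured. Its structure departs from that of compound 2 by one exchange: iodo in place of chloro on an aromatic carbon. For the measured compounds named here, no step between measured compounds is available to calibrate this exchange. The working expectation is therefore a change within the scatter, leaning if anything toward a lower number. The expected step is a 1.1-fold lower number from compound 2 to compound 3 (0.05 log units; within the scatter) and it stays within the scatter. For compound 3 the estimated value is 8000 nM (expected range 3500 nM to 20000 nM) in this assay.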

Compound 3, half-maximal inhibitory concentration: 6920 nM
For compound 3 the middle estimate is 1.2-fold (0.06 log units) above the measured one, within the range that was stated.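

In this assay the series gains its first readable step: iodo in place of chloro on an aromatic carbon, meta to a large group, gives a 1.3-fold lower number from compound 2 to compound 3 (0.12 log units; within the scatter). At this place, compound 2 and compound 3 therefore cannot be told apart on this read-out, although the exchange replaces one halogen with a heavier one; neither group brings a hydrogen-bond donor, a hydrogen-bond acceptor or a net charge. Nothing available bears on the reason for this result.

With no number for compound 1, the effect of either halogen relative to hydrogen at this place cannot be read. Going by these compounds, it also remains open whether an amine, a carboxylic acid or a longer chain at this place would depart from the two halogens.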